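The source may report more compounds than this note shows. Statements on the series, on what has been measured and on what is new or still open speak of the compounds shown alone.

Measured compounds:
compound 1, `COc1ccc(-c2cc(/C=C/C(=O)c3ccc(N)cc3)[nH]n2)cc1`, 1470 nM in a functional assay on T47D cells (Homo sapiens) for inhibition, read by sulforhodamine B assay, with a stated time of 48 h; on this read-out lower numbers stand for stronger inhibition of growth and higher numbers for weaker inhibition of growth
compound 2, `COc1ccc(-c2cc(/C=C/C(=O)c3ccc(N)cc3)[nH]n2)cc1OC`, 4250 nM
compound 3, `COc1cc(C(=O)/C=C/c2cc(-c3cc(OC)c(OC)c(OC)c3)n[nH]2)cc(OC)c1OC`, 1130 nM

Compound 3 stands lowest of the three in this assay, though its gap to compound 1 is within the scatter, while compound 2 lies beyond it. Between compound 2 and compound 1 one change is made, (hydrogen in place of methoxy on an aromatic carbon), and it gave a 2.9-fold lower number from compound 2 to compound 1 (0.46 log units; beyond the scatter). The difference between the core of compound 3 and that of compound 2 is not broken down here.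

Compound 4, `COc1ccc(-c2cc(/C=C/C(=O)c3cc(OC)c(OC)c(OC)c3)[nH]n2)cc1OC`, has not been measured. It arises from compound 3 by hydrogen in place of methoxy on an aromatic carbon. For the measured compounds named here, this is the same kind of change as the one from compound 2 to compound 1, not the same: in compound 3 the place is also meta to a methoxy group, which it is not in compound 2. The step expected from compound 3 to compound 4, a 1.9-fold lower number from compound 3 to compound 4 (0.27 log units; within the scatter), rests on a 2.9-fold lower number from compound 2 to compound 1 (0.46 log units; beyond the scatter) and is taken as somewhat smaller, the surroundings differing. Compound 4 is thus expected to give 600 nM, with the likely range 250 nM to 1500 nM.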

Compound 4, concentration for 50% growth inhibition: 1010 nM
The estimate for compound 4 lay 1.7-fold (0.23 log units) below the measured number, and the stated range covers the measured number.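

In this assay, the exchange of methoxy for hydrogen on an aromatic carbon, carried to a second core, gave a 1.1-fold lower number from compound 3 to compound 4 (0.05 log units; within the scatter), so on that core the change has no effect that can be told from the scatter. Set beside the first case, the two steps do not differ by more than repeated measurements allow: the same change on two cores in this assay, a 2.9-fold lower number (0.46 log units; beyond the scatter) from compound 2 to compound 1 and a 1.1-fold lower number (0.05 log units; within the scatter) from compound 3 to compound 4, 2.6-fold (0.41 log units) apart, within the scatter of two such steps. This means the series shows no clear conflict in carrying the change from one core to the other, but two pairs do not establish that the step has one common size, and they say nothing of any further core.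

The compounds shown leave open whether the same place would respond in a comparable way to a hydroxy group, a fluorine atom or an ethoxy group instead of methoxy or hydrogen. They also leave open how the change would read on a core carrying a carboxylic acid where compound 1 carries its amine.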